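Adding a Methyl on a Thioether Chain of a Shared Core

The compounds below may be only part of what the source reports. "The series", "measured", "known", "first", "only" and "open" are said of these compounds alone.

Measured compounds:
- compound 1, `Cc1cccc(Nc2cc(Cl)nc(SC(C(=O)O)c3ccccc3)n2)c1C`: "not active" (no number reported)
- compound 2, `CCOC(=O)CSc1nc(Cl)cc(Nc2ccc3ncccc3c2)n1`: 86.3%
- compound 3, `CCCCCCC(Sc1nc(Cl)cc(Oc2ccc3ncccc3c2)n1)C(=O)O`: 91.4%

All three compounds were tested in an assay for inhibition of Polyunsaturated fatty acid 5-lipoxygenase (Homo sapiens), tested at 1 uM; a higher number here means a weaker effect of the compound at the concentration tested, a lower number a stronger effect. Compound 1, `Cc1cccc(Nc2cc(Cl)nc(SC(C(=O)O)c3ccccc3)n2)c1C`, is reported in this assay only as "not active" (no number reported), without a number. Compound 2, `CCOC(=O)CSc1nc(Cl)cc(Nc2ccc3ncccc3c2)n1`, gives 86.3%. Compound 3, `CCCCCCC(Sc1nc(Cl)cc(Oc2ccc3ncccc3c2)n1)C(=O)O`, gives 91.4%. Within the data shown here, of the two numbers, the one for compound 2 is the smaller, but the gap to compound 3 falls within the usual scatter of such measurements, so the two cannot be told apart. Both numbers are high, which means that at the tested concentration neither compound does much.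

Compound 4, `CCOC(=O)C(C)Sc1nc(Cl)cc(Nc2ccc3ncccc3c2)n1`, has not yet been measured. It differs from compound 2 in one place: methyl in place of hydrogen on a saturated chain carbon bound to a carbonyl carbon and a sulfur. Among the measured compounds shown here, no step between two measured compounds shows what such a change does here. With only a methyl entering, and compound 2 already showing little effect at 86.3%, the expectation for compound 4 is a step of no size beyond the scatter, in either direction: a number 1.3 percentage points lower from compound 2 to compound 4 (within the scatter). Compound 4 is therefore estimated to give about 85%, within a range from 70% to 100%.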

Compound 4, a percentage reported as activity, at one concentration (the size of the read-out at that concentration, not a potency): "not active" (no number reported)
No number was reported for compound 4; no gap can be computed for the estimate.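

In this assay compound 4 stands as "not active" (no number reported) and so, without a number to set against compound 2, no new step can be read. Nothing shown here bears on this result. The compounds shown leave open how large the effect of methyl in place of hydrogen on this chain carbon is, and in which direction it runs.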